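The compounds below may be only part of what the source reports. "The series", "measured", "known", "first", "only" and "open" are said of these compounds alone.

Of the compounds shown here, three built on one shared core have been tested in a functional assay on PC-3 cells (Homo sapiens) for inhibition, read by MTT assay, with a stated time of 72 h; on this read-out lower numbers stand for stronger inhibition and higher numbers for weaker inhibition. Compound 1 `C#CCSc1nc(NCCC(C)C)c2ccncc2n1` carries an isopentyl group on a nitrogen on an aromatic ring; in this assay compound 1 reaches only the limit of the assay, > 80000 nM, not a number. Compound 2 `C#CCSc1nc(Nc2ccc(F)cc2)c2ccncc2n1` carries a 4-fluorophenyl group at that nitrogen, and in this assay compound 2 gives 17300 nM. Compound 3 `C#CCSc1nc(Nc2cccc(Cl)c2)c2ccncc2n1` carries a 3-chlorophenyl group there, and in this assay compound 3 gives 56500 nM. Of the two numbers, compound 2 has the lower one; the step of a 3.3-fold higher number from compound 2 to compound 3 (0.51 log units; beyond the scatter) is modest, and the step of an at least 4.6-fold lower number from compound 1 to compound 2 (0.66 log units; beyond the scatter) is only a floor. Compound 4 `C#CCSc1nc(Nc2ccc([N+](=O)[O-])cc2)c2ccncc2n1` is not yet measured. It differs from compound 2 by nitro in place of fluoro on an aromatic carbon. Going by the values given here, no measured step swaps one group for another at this place; the nearest guide is a 3.3-fold higher number from compound 2 to compound 3 (0.51 log units; beyond the scatter), which moved the number modestly. A change of similar size in either direction, or none beyond the scatter, is therefore plausible. The estimate for compound 4 in this assay is 20000 nM, between 6000 nM and 60000 nM, which would mean an expected step of a 1.2-fold higher number from compound 2 to compound 4 (0.06 log units; within the scatter).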

Compound 4, half-maximal inhibitory concentration: > 80000 nM
Compound 4: a limit, no number; the forecaster's own chance of this, stated with the estimate: 15%; middle value at least 4.0-fold (0.60 log units) from the limit.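

Earlier compounds changed the whole group on the nitrogen, whereas compound 4 keeps the phenyl ring and changes only what sits on it, para to a large group. In this assay that single swap matters, since nitro in place of fluoro gives an at least 4.6-fold higher number from compound 2 to compound 4 (0.66 log units; beyond the scatter), so this position does not accept every group alike. Compound 4 gives a limit, not a number, so this step is only a floor and its true size cannot be read: the limit of > 80000 nM in this assay, at which 2 of the 4 values shown sit.

As far as these compounds go, it stays open whether any group at this position gives a lower number than fluoro does in compound 2. An amino group or a methoxy group there would show whether the weaker result goes with nitro in particular or with replacing fluoro at all.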